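Naphthalen-1-yl Enters an Otherwise Inactive Compound

A few compounds are considered here, and "the series" means these few. Any claim that something is new, unique, unknown or untested is made for them only; others in the source may bear on it.

Compound 1: `CC(C)(C)SCCNC(=S)c1cccc(C(=S)NCCSC(C)(C)C)n1` — 37000 nM
Compound 2: `O=C(O)CCNC(=O)c1cccc(C(=O)NCCC(=O)O)n1` — > 100000 nM

Of the compounds shown here, two have so far been tested in an ADME assay on Vero cells (Chlorocebus sabaeus) for cytotoxicity, read by resazurin assay, with a stated time of 69 h; on this read-out lower numbers stand for higher toxicity in this test and higher numbers for lower toxicity in this test. Compound 1 `CC(C)(C)SCCNC(=S)c1cccc(C(=S)NCCSC(C)(C)C)n1` gives 37000 nM. Compound 2 `O=C(O)CCNC(=O)c1cccc(C(=O)NCCC(=O)O)n1` gives only a limit, > 100000 nM, not a number. That limit is where one of the two values sits (the limit of > 100000 nM in this assay, at which 1 of the 2 values shown sits). Among the compounds with values here, compound 1 and compound 2 differ in several places at once, so no single step between them can be drawn from these two values.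

Compound 3 `O=C(O)CCNC(=O)c1cc(-c2cccc3ccccc23)cc(C(=O)NCCC(=O)O)n1` is the untested compound. It comes from compound 2 by one change: naphthalen-1-yl in place of hydrogen on an aromatic carbon. Within the data shown here, no measured step of this kind exists among the compounds here, so the size of the effect carries real uncertainty. The expectation for compound 3 is a modest move toward higher toxicity, a downward step an at least 1.6-fold lower number from compound 2 to compound 3 (0.22 log units; that floor lies within the scatter), while a result that again stops at the limit remains quite possible. Compound 3 is therefore estimated at 60000 nM, with a range from 20000 nM to 150000 nM.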

Compound 3, half-maximal cytotoxic concentration: > 100000 nM
Compound 3: a limit, no number; the forecaster's own chance of this, stated with the estimate: 40%; at least 1.6-fold (0.22 log units) between middle value and limit.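

In this assay, within the data shown here, compound 3 gives only a limit, not a number, just as compound 2 does, so no step from compound 2 to compound 3 can be read: the limit of > 100000 nM in this assay, at which 2 of the 3 values shown sit. The compounds shown leave open whether naphthalen-1-yl in place of hydrogen on an aromatic carbon changes the toxicity in this test at all, and in which direction.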